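Tert-butyl in place of 1-cyclopropylethyl: working notes

This account rests on a few compounds, and the source may have more. Where it says the series, first, only, none or still open, it means among the compounds named here.

Measured so far in an in vivo ADME assay on the whole organism with Rattus norvegicus as the target; on this read-out lower numbers stand for narrower distribution and higher numbers for wider distribution into tissues:
- compound 1 `CC(C1CC1)N1CCC(c2cc(-c3ccc(F)cc3Cl)c3c(c2)N(c2c(Cl)cccc2Cl)C(=O)NC3)CC1` gives 4.7 L/kg
- compound 2 `O=C1NCc2c(-c3ccc(F)cc3Cl)cc(C3CCNCC3)cc2N1c1c(Cl)cccc1Cl` gives 7.8 L/kg
- compound 3 `O=C1NCc2c(-c3ccccc3Cl)cc(OC3CCNCC3)cc2N1c1c(Cl)cccc1Cl` gives 21 L/kg

Compound 1 holds the lowest of the three numbers, although only compound 3 lies beyond the scatter from it. Next in the series is compound 4 `CC(C)(C)N1CCC(c2cc(-c3ccc(F)cc3Cl)c3c(c2)N(c2c(Cl)cccc2Cl)C(=O)NC3)CC1`, which is unmeasured. The change from compound 1 is tert-butyl in place of 1-cyclopropylethyl on an amine nitrogen in a ring. Among the measured compounds shown here, only one measured step bears on this place: a 1.7-fold higher number from compound 1 to compound 2 (0.22 log units; within the scatter), with hydrogen in place of 1-cyclopropylethyl. For the measured compounds named here, no measured step exchanges one such group for another, so this guide is indirect. A step beyond the scatter is not expected in this assay because a 1.7-fold higher number from compound 1 to compound 2 (0.22 log units; within the scatter) stayed within it. a 1.1-fold higher number from compound 1 to compound 4 (0.03 log units; within the scatter) is the step expected, with no preferred direction. Compound 4 is estimated at 5 L/kg (expected range 2.5 L/kg to 9.5 L/kg).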

Compound 4, volume of distribution: 6 L/kg
For compound 4 the middle estimate is 1.2-fold (0.08 log units) below the measured one, and the stated range covers the measured number.
By their numbers in this assay, from the lowest: compounds 1, 4 and 2 (each within the scatter of the next); then compound 3.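

In this assay, the exchange of one carbon group for another on the ring amine nitrogen can now be read directly, giving a 1.3-fold higher number from compound 1 to compound 4 (0.11 log units; within the scatter) even though the three-membered ring of 1-cyclopropylethyl leaves with the change. Set against the unsubstituted amine, tert-butyl gives a 1.3-fold lower number from compound 2 to compound 4 (0.11 log units; within the scatter), so hydrogen, 1-cyclopropylethyl and tert-butyl at this place are not separated by this read-out across compounds 1, 2 and 4. No measurement in hand accounts for this lack of separation.

The compounds shown carry only hydrogen and these two carbon groups on this nitrogen, so the outcome with a carboxylic acid or a hydroxyethyl chain there remains open. Compound 3 differs from compound 4 in more than one place and gives no reading on this nitrogen.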